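Benzyl versus phenyl on the shared core: a small step

A few compounds are considered here, and "the series" means these few. Any claim that something is new, unique, unknown or untested is made for them only; others in the source may bear on it.

In a functional assay on HeLa cells (Homo sapiens) for inhibition, read by cell counting, with a stated time of 4 days (a higher number here means a weaker inhibitor, a lower number a stronger inhibitor), compound 3 `C=C(Br)C(=O)Nc1cccc(-c2cn3nc(-c4ccc(OC)cc4)sc3n2)c1` gives 2300 nM. Compound 1 `C=C(Br)C(=O)Nc1cccc(-c2cn3nc(Cc4cccc(OC)c4)sc3n2)c1` gives 2500 nM and compound 2 `C=C(Br)C(=O)Nc1cccc(-c2cn3nc(Cc4ccc(Cl)cc4)sc3n2)c1` gives 2700 nM in this assay. Compound 3 thus shows the lowest of the three numbers, yet its gaps to both companions are within the scatter, so no ranking can be drawn from them. Compound 4 `C=C(Br)C(=O)Nc1cccc(-c2cn3nc(Cc4ccc(OC)cc4)sc3n2)c1` has not been measured; it differs from compound 3 by 4-methoxybenzyl in place of 4-methoxyphenyl on an aromatic carbon. Among the compounds with values here, two measured steps bear on this change, since each swaps a benzyl for a phenyl on the same carbon of the core: a 1.1-fold lower number from compound 1 to compound 3 (0.04 log units; within the scatter) and a 1.2-fold lower number from compound 2 to compound 3 (0.07 log units; within the scatter). Neither reached beyond the scatter, and the substituent pattern on the six-membered ring also left the numbers untouched across compounds 1 and 2. On this basis compound 4 is expected to give 2500 nM, within a range of 1200 nM to 5200 nM. The expected step is therefore a 1.1-fold higher number from compound 3 to compound 4 (0.04 log units; within the scatter), which is not beyond the scatter.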

Compound 4, half-maximal inhibitory concentration: 2300 nM
The estimate for compound 4 lay 1.1-fold (0.04 log units) above the measured number; low and high end bracket the measured number.
By their numbers in this assay, from the lowest: compounds 3, 4, 1 and 2 (each within the scatter of the next).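

With the 4-methoxy group held constant, compound 4 isolates the benzyl-for-phenyl exchange at this carbon of the shared core, and in this assay the result is no change at the digits printed from compound 3 to compound 4 (within the scatter) and so no sign that this carbon responds to the exchange. The earlier steps shown here of this kind also changed the substituent on the six-membered ring, whereas compound 4 also allows that substituent to be read alone on the benzyl series: methoxy in place of chloro gives a 1.2-fold lower number from compound 2 to compound 4 (0.07 log units; within the scatter) and 4-methoxyphenyl in place of 3-methoxyphenyl on the chain carbon gives a 1.1-fold lower number from compound 1 to compound 4 (0.04 log units; within the scatter) and neither step is beyond the scatter. No measurement offered here accounts for this flatness. The compounds shown leave open whether an amine or a carboxylic acid on the six-membered ring, or a longer chain joining that ring to the core, would move the number beyond the scatter.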